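The source may report more compounds than this note shows. Statements on the series, on what has been measured and on what is new or still open speak of the compounds shown alone.

Working notes on the series. Of the compounds shown here, three have been measured: compound 1 `CNc1nc(NCC(C)(C)C)cc(-c2ccccn2)n1`, compound 2 `c1ccc(-c2cc(NCC3CC3)ncn2)nc1` and compound 3 `CNc1nc(NCc2ccc(S(C)(=O)=O)cc2)cc(-c2ccccn2)n1`; a fourth, compound 4 `COCCNc1nc(NCC2CC2)cc(-c2ccccn2)n1`, has not. In a functional assay on HEK293 cells for agonist activity at G-protein coupled receptor 39 (Homo sapiens), read by inositol phosphate accumulation (a higher number here means that more compound is needed for the effect, a lower number that less compound is needed), compound 1 gives 73 nM, compound 3 gives 36 nM, and compound 2 gives 22000 nM. Compound 2 thus stands at the highest of the three values, and both gaps lie beyond the scatter: its number is far above that of compound 1 and further still above that of compound 3. Compound 1 and compound 3 both carry a methylamino group on the aromatic carbon between two ring nitrogen atoms of the shared core, whereas compound 2 carries only hydrogen at that carbon.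

The move to compound 4 addresses exactly that site: (2-methoxyethyl)amino in place of hydrogen on an aromatic carbon. The (cyclopropylmethyl)amino group and the pyridin-2-yl group remain as in compound 2. Going by the values given here, no measured pair shows this particular substitution, so the expectation rests on how far compound 2 sits above compound 1 and compound 3. For compound 4 a large downward step is expected, a 220-fold lower number from compound 2 to compound 4 (2.34 log units; beyond the scatter), well beyond the scatter. In this assay compound 4 is estimated at 100 nM, with a likely range from 30 nM to 400 nM.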

Compound 4, half-maximal effective concentration: 2200 nM
For compound 4 the middle estimate is 22-fold (1.34 log units) below the measured one; measured number outside the range, above it.
By their numbers in this assay, from the lowest: compound 3; then compound 1; then compound 4; then compound 2.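

In this assay, placing (2-methoxyethyl)amino instead of hydrogen on the aromatic carbon between two ring nitrogen atoms, with the (cyclopropylmethyl)amino and pyridin-2-yl groups unchanged, gives a 10-fold lower number from compound 2 to compound 4 (1.00 log units; beyond the scatter). Going by these compounds alone, this is the first reading of this position in which nothing else changes. Compound 2 differs from compound 1 and compound 3 in more than one place. It shows that this carbon accepts a substituent of this size and that the substituent alone lowers the number by a modest step beyond the scatter, while the compounds shown offer no measurement that accounts for the size of that step.

Compound 4 also differs from compound 1 and compound 3 in more than one place, so the effect of (2-methoxyethyl)amino relative to methylamino at this carbon cannot be separated from that of the other amino group. Also open, on these data alone, is how a plain amino group, a dimethylamino group or a longer ether chain on the amine nitrogen at this carbon would compare with (2-methoxyethyl)amino while the (cyclopropylmethyl)amino group stays in place.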